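The source may report more compounds than this note shows. Statements on the series, on what has been measured and on what is new or still open speak of the compounds shown alone.

Measured in an in vivo ADME assay on the whole organism (strain Mongrel) for pharmacokinetics, with Canis familiaris (Canis lupus familiaris) as the target; on this read-out lower numbers stand for slow clearance and higher numbers for fast clearance:
compound 1 `C[C@@H](NC(=O)C1(NC(=O)c2cncc(Br)c2)CC1)c1ccc(-n2nc(Cl)c3ccccc32)cc1F` gives 3.8 mL/min/kg
compound 2 `Cc1nnsc1C(=O)NC1(C(=O)N[C@H](C)c2ccc(-n3nc(Cl)c4ccccc43)cc2F)CC1` gives 9.6 mL/min/kg
compound 3 `C[C@@H](NC(=O)C1(NC(=O)c2cncs2)CC1)c1ccc(-n2nc(Cl)c3ccccc32)cc1F` gives 1.1 mL/min/kg

Compound 3 stands lowest of the three in this assay; the step of a 3.5-fold lower number from compound 1 to compound 3 (0.54 log units; beyond the scatter) and the step of an 8.7-fold lower number from compound 2 to compound 3 (0.94 log units; beyond the scatter) both run downward to it, both beyond the scatter, while a 2.5-fold higher number from compound 1 to compound 2 (0.40 log units; beyond the scatter) runs the other way. The next compound, compound 4 `COc1ncc(C(=O)NC2(C(=O)N[C@H](C)c3ccc(-n4nc(Cl)c5ccccc54)cc3F)CC2)s1`, takes the change (methoxy in place of hydrogen on an aromatic carbon). For the measured compounds named here, none of the measured steps touches this change: all three swap the whole ring on the carbonyl carbon, none adds a group to the ring that compound 3 and compound 4 share. Going by the values given here, with no step bearing on it, no shift beyond the scatter is expected, and the estimated step of a 1.4-fold higher number from compound 3 to compound 4 (0.13 log units; within the scatter) stays small. Compound 4 is estimated at 1.5 mL/min/kg, with a range from 0.6 mL/min/kg to 4 mL/min/kg.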

Compound 4, clearance: 1.7 mL/min/kg
The estimate for compound 4 lay 1.1-fold (0.05 log units) below the measured number, within the range that was stated.
By their numbers in this assay, from the lowest: compounds 3 and 4 (each within the scatter of the next); then compound 1; then compound 2.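

In this assay, the 2-methoxy-1,3-thiazol-5-yl ring stays within the scatter of the unsubstituted ring, with methoxy in place of hydrogen on the carbon next to the ring nitrogen and the ring sulfur (a 1.5-fold higher number from compound 3 to compound 4 (0.19 log units; within the scatter)). The methoxy ring also keeps compound 4 clear of the other two rings (a 5.6-fold lower number from compound 2 to compound 4 (0.75 log units; beyond the scatter)) and (a 2.2-fold lower number from compound 1 to compound 4 (0.35 log units; beyond the scatter)), both beyond the scatter. Nothing available explains these numbers.

Open, as far as these compounds go, is whether an amine or a longer chain such as ethoxy on this same carbon would also stay within the scatter of compound 3.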